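This account rests on a few compounds, and the source may have more. Where it says the series, first, only, none or still open, it means among the compounds named here.

Compound 1, `COc1cc(-n2ncnc2-c2ccc(OC(C)C)cc2)cc(OC)c1OC`, is the reference point here. Within the data shown here, in a functional assay on HeLa cells (Homo sapiens) for antiproliferative activity, read by MTT assay, with a stated time of 72 h (on this read-out higher numbers stand for weaker inhibition and lower numbers for stronger inhibition), compound 1 gives 600 nM, and this is the only plain number in the set. Compound 2, `COc1cc(-c2ncnn2-c2ccc(F)cc2)cc(OC)c1OC`, is a different case: in this assay compound 2 returns only > 10000 nM, which is a limit of the assay rather than a measured value, so of the two values shown one sits at the limit of > 10000 nM in this assay, at which 1 of the 2 values shown sits.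

Compound 3, `CCOc1ccc(-c2ncnn2-c2cc(OC)c(OC)c(OC)c2)cc1`, has not yet been measured. It differs from compound 1 in one place: hydrogen in place of methyl on a saturated chain carbon bound to an oxygen on an aromatic ring and a saturated chain carbon. Among the measured compounds shown here, since no pair of measured compounds shows the effect of this kind of change, the expectation rests on compound 1 alone. The step from compound 1 to compound 3 is estimated as a 1.3-fold higher number from compound 1 to compound 3 (0.12 log units; within the scatter), which stays within the usual scatter of such measurements. Compound 3 is therefore expected to give about 800 nM in this assay, somewhere between 300 nM and 2500 nM.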

Compound 3, half-maximal inhibitory concentration: 15 nM
Estimate against measurement, compound 3: 53-fold (1.73 log units) above; the measured number lies below the stated range.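

In this assay the change from isopropoxy to ethoxy removes a single methyl and gives a 40-fold lower number from compound 1 to compound 3 (1.60 log units; beyond the scatter) as its step. No ring, hydrogen-bond donor, hydrogen-bond acceptor or charge is involved in this difference, yet the read-out moves strongly towards greater inhibition. This shows that the read-out is highly sensitive to a small edit at this saturated chain carbon, something the earlier compounds could not show, and nothing measured here explains why.

Only isopropoxy and ethoxy can be compared on the shared core, so two points do not establish a trend with chain size. Going by these compounds, what a methoxy group, a longer chain such as propoxy, or an ethoxy chain ending in an amine would give at this place remains open.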